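Swapping Dimethoxyphenyl for Chlorophenyl: An Expected Weaker Effect

A few compounds are considered here, and "the series" means these few. Any claim that something is new, unique, unknown or untested is made for them only; others in the source may bear on it.

Compound 1 `Cc1nc(-c2ccccc2)sc1C(=O)CSc1nc(-c2ccccc2)c(C#N)c(=O)[nH]1`: 77.5%
Compound 2 `COc1ccc(-c2nc(SCC(=O)c3sc(-c4ccccc4)nc3C)[nH]c(=O)c2C#N)cc1OC`: 21.4%
Compound 3 `COc1ccc(-c2nc(SCC(=O)c3sc(-c4ccc(Cl)cc4)nc3C)[nH]c(=O)c2C#N)cc1OC`: 59.8%

Three compounds sharing one core were tested in a functional assay on U-87MG ATCC cells for antiproliferative activity against U-87 MG (Homo sapiens), read by MTT assay, with a stated time of 48 h, tested at 50 uM; a lower number here means a stronger effect, a higher number a weaker effect of the compound at the concentration tested. Compound 2 stands lowest of the three, its nearest neighbour being compound 3 and the furthest compound 1, both steps beyond the scatter. Compound 4 `Cc1nc(-c2ccccc2)sc1C(=O)CSc1nc(-c2cccc(Cl)c2)c(C#N)c(=O)[nH]1` is not yet measured; it differs from compound 2 in one place: 3-chlorophenyl in place of 3,4-dimethoxyphenyl on an aromatic carbon.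

Among the measured compounds shown here, two measured steps bear on this change. The first, a number 56.1 percentage points lower from compound 1 to compound 2 (beyond the scatter), shows that bringing in the 3,4-dimethoxyphenyl in place of phenyl gave the lowest number of the set; compound 4 gives that group up again. The second, a number 38.4 percentage points higher from compound 2 to compound 3 (beyond the scatter), shows that adding a chloro on an aromatic carbon, though on the other phenyl, raised the number strongly. Both point the same way, so a large rise in this assay is expected from compound 2 to compound 4, towards the level of compound 1. Compound 4 is estimated at 70%, within 45% to 95%, an expected step of a number 48.6 percentage points higher from compound 2 to compound 4 (beyond the scatter).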

Compound 4, a percentage reported as activity, at one concentration (the size of the read-out at that concentration, not a potency): 50.6%
Compound 4: middle estimate off by 19.4 percentage points, on the high side; measured number inside the range.
By their numbers in this assay, from the lowest: compound 2; then compounds 4 and 3 (each within the scatter of the next); then compound 1.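

At this position, the aromatic carbon next to the ring nitrogen and ortho to the cyano group, a substituted phenyl does not simply behave like plain phenyl in this assay: the 3-chlorophenyl of compound 4 gives a number 26.9 percentage points lower from compound 1 to compound 4 (beyond the scatter). The two substituted phenyls are not equivalent either, since the change from 3,4-dimethoxyphenyl to 3-chlorophenyl gives a number 29.2 percentage points higher from compound 2 to compound 4 (beyond the scatter). A chloro on an aromatic carbon therefore has no single direction across these compounds, as it moves the number up on one phenyl and down on the other: the same change on two cores in this assay, a number 38.4 percentage points higher (beyond the scatter) from compound 2 to compound 3 and a number 26.9 percentage points lower (beyond the scatter) from compound 1 to compound 4, 65.3 percentage points apart, beyond the scatter of two such steps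

As far as these compounds go, whether one methoxy alone on this phenyl would give a number like that of compound 2 remains open. So does the effect of an amine or a carboxylic acid on the same ring.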